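The source may report more compounds than this note shows. Statements on the series, on what has been measured and on what is new or still open speak of the compounds shown alone.

Measured so far in a functional assay on liver (Sus scrofa) for inhibition of squalene monooxygenase (Homo sapiens), using microsomes; on this read-out lower numbers stand for stronger inhibition and higher numbers for weaker inhibition:
compound 1 `CCN(C/C=C/C#CC(C)(C)C)Cc1cccc(OC[Si](C)(C)c2ccc(Br)cc2)c1` — 210 nM
compound 2 `CCN(C/C=C/C#CC(C)(C)C)Cc1cccc(OC[Si](C)(C)c2cccc(C)c2)c1` — 3000 nM
compound 3 `CCN(C/C=C/C#CC(C)(C)C)Cc1cccc(OC[Si](C)(C)c2ccc(O)cc2)c1` — 8000 nM

Compound 3 gives the highest number of the three in this assay. Its nearest neighbour is compound 2 and its furthest is compound 1. The steps read a 2.7-fold higher number from compound 2 to compound 3 (0.43 log units; beyond the scatter) and a 38-fold higher number from compound 1 to compound 3 (1.58 log units; beyond the scatter), both beyond the scatter; the exchange on the silicon-bound ring between the other two, a 14-fold higher number from compound 1 to compound 2 (1.15 log units; beyond the scatter), is large as well.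

Compound 4 `CCN(C/C=C/C#CC(C)(C)C)Cc1cccc(OC[Si](C)(C)c2ccc(C(N)=O)cc2)c1` keeps the core of compound 3 and differs at one aromatic carbon: carbamoyl in place of hydroxy on an aromatic carbon. For the measured compounds named here, no measured step covers a carbamoyl group. What bears on the change is that both exchanges leading into compound 3 moved the number beyond the scatter, so the group at this place does matter in this assay, while the direction for carbamoyl is left open by the data. A number close to that of compound 3 is therefore expected, a 1.6-fold lower number from compound 3 to compound 4 (0.20 log units; within the scatter), with a wide range on either side. Compound 4 is estimated at 5000 nM, between 1500 nM and 20000 nM.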

Compound 4, half-maximal inhibitory concentration: 5000 nM
Estimate against measurement, compound 4: no gap at the digits printed; the range from low to high includes it.
By their numbers in this assay, from the lowest: compound 1; then compounds 2, 4 and 3 (each within the scatter of the next, the first and the last beyond it).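

In this assay, carbamoyl para to a large group reads level with hydroxy (a 1.6-fold lower number from compound 3 to compound 4 (0.20 log units; within the scatter)), so three heavy atoms in place of one leave the number within the scatter. Compound 4 also lies within the scatter of the 3-methylphenyl compound (a 1.7-fold higher number from compound 2 to compound 4 (0.22 log units; within the scatter)), while the gap to bromo remains large (a 24-fold higher number from compound 1 to compound 4 (1.38 log units; beyond the scatter)), so exchanging hydroxy for carbamoyl does not close it. No measured evidence here accounts for these results.

On these data alone, whether chloro, methyl or a carboxylic acid at this same place would fall near compound 1 or near compound 4 remains open. As far as these compounds go, the effect of the methyl group's location also remains open, since 3-methylphenyl is compared here only with rings carrying a different group at another place.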